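The source may report more compounds than this note shows. Statements on the series, on what has been measured and on what is new or still open speak of the compounds shown alone.

Measured in a functional assay on MDA-MB-231 cells (Homo sapiens) for antiproliferative activity, read by MTT assay, with a stated time of 72 h; a higher number here means a weaker inhibitor, a lower number a stronger inhibitor:
- compound 1 `O=C(CCc1cccc2c1B(O)OC2)Nc1ccc(Cl)cc1`: 3600 nM
- compound 2 `Cc1ccc(NC(=O)CCc2cccc3c2B(O)OC3)cc1`: 1100 nM
- compound 3 `CC(C)(C)OC(=O)Nc1ccc(NC(=O)CCc2cccc3c2B(O)OC3)cc1`: 29000 nM

Compound 3 has the highest number of the three, which makes it the weakest inhibitor so far. Compound 4 `O=C(CCc1cccc2c1B(O)OC2)Nc1ccc([N+](=O)[O-])cc1` keeps the shared core and changes one group, with nitro in place of (tert-butoxycarbonyl)amino on an aromatic carbon.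

Among the measured compounds shown here, two measured steps bear on this change, as both bring in the group that compound 4 loses. One is modest, an 8.1-fold higher number from compound 1 to compound 3 (0.91 log units; beyond the scatter), and the other is large, a 26-fold higher number from compound 2 to compound 3 (1.42 log units; beyond the scatter). Neither step involves nitro, so the data do not show how that group itself behaves. Even so, removing the (tert-butoxycarbonyl)amino group should bring the result closer to the values of compound 1 and compound 2, so a clearly lower number is expected in this assay.

The expected change is a 9.7-fold lower number from compound 3 to compound 4 (0.99 log units; beyond the scatter).

For compound 4 the estimated value is 3000 nM, with an expected range from 900 nM to 12000 nM.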

Compound 4, half-maximal inhibitory concentration: 36000 nM
Beside the measured number, compound 4's estimate is 12-fold (1.08 log units) below it; the whole stated range lies below it.
By their numbers in this assay, from the lowest: compound 2; then compound 1; then compounds 3 and 4 (each within the scatter of the next).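

In this assay, nitro in place of (tert-butoxycarbonyl)amino gives a 1.2-fold higher number from compound 3 to compound 4 (0.09 log units; within the scatter), so a group with far fewer heavy atoms leaves the result within the scatter, and heavy-atom count alone does not sort these compounds. Nitro also stands well apart from the other two small groups, with a 10-fold higher number from compound 1 to compound 4 (1.00 log units; beyond the scatter) for the change from chloro and a 33-fold higher number from compound 2 to compound 4 (1.51 log units; beyond the scatter) for the change from methyl, which shows that this position tells small groups apart. No measured evidence here explains why these groups differ.

Still open, on these data alone, is where an amine or a methoxy group at this position would fall: with methyl and chloro, or with nitro and (tert-butoxycarbonyl)amino. A carboxylic acid there would test the same question with a different kind of group.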